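Adding a Hydroxy Group to Compound 1: Expected Outcome

This account rests on a few compounds, and the source may have more. Where it says the series, first, only, none or still open, it means among the compounds named here.

Measured compounds and their values:
compound 1 `COc1cccc(C2SCC(=O)N2c2nnc(CNn3c(C)nc4ccccc4c3=O)s2)c1` gives 60%
compound 2 `Cc1nc2ccccc2c(=O)n1NCc1nnc(/N=C/c2ccc(O)cc2)s1` gives 50%
compound 3 `Cc1nc2ccccc2c(=O)n1NCc1nnc(/N=C/c2ccccc2)s1` gives 50%

All three were tested in a functional assay on the whole organism (strain albino) with Rattus norvegicus as the target, in the maximal electroshock model, with a stated time of 1 h, at a dose of 30 mg/kg by the intraperitoneal route; on this read-out lower numbers stand for less inhibition and higher numbers for more inhibition at the one dose given (going by the name of the read-out). Compound 1 holds the highest of the three numbers, yet compound 2 and compound 3 both lie within the usual scatter of it, so no ordering among them can be claimed. The unmeasured compound 4 `COc1cc(C2SCC(=O)N2c2nnc(CNn3c(C)nc4ccccc4c3=O)s2)ccc1O` differs from compound 1 by hydroxy in place of hydrogen on an aromatic carbon. For the measured compounds named here, one measured step bears on this change: no change at the digits printed from compound 2 to compound 3 (within the scatter), which is the same kind of change run the other way, a hydroxy on an aromatic carbon removed rather than added. Because no change at the digits printed from compound 2 to compound 3 (within the scatter) stayed within the scatter, the step of no change at the digits printed from compound 1 to compound 4 (within the scatter) is expected to stay within the scatter too. Compound 4 is therefore estimated at 60%, within a range from 45% to 75%.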

Compound 4, a percentage reported as inhibition, in the whole organism at one dose (the size of the read-out at that dose, not a potency): 60%
For compound 4 middle estimate and measured number coincide at the digits printed; measured number inside the range.
By their numbers in this assay, from the lowest: compounds 2, 3, 1 and 4 (each within the scatter of the next).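

In this assay, turning the 3-methoxyphenyl group into 4-hydroxy-3-methoxyphenyl gives no change at the digits printed from compound 1 to compound 4 (within the scatter). So a carbon ortho to a methoxy group and para to a large group takes a hydroxy in place of hydrogen with no visible shift in this assay. The change now reads alike in both settings: the same change on two cores in this assay, no change at the digits printed (within the scatter) from compound 2 to compound 3 and no change at the digits printed (within the scatter) from compound 4 to compound 1, 0 percentage points apart, within the scatter of two such steps. The compounds shown leave open whether an amine or a carboxylic acid on this same carbon would also leave the number in place. From the compounds shown here alone, whether a longer chain in place of the methoxy group would do so stays open too.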